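Shortening the nitrooxy chain of compound 2

The source may hold more compounds than are shown below. What is called first, only, known or untested is meant among the compounds shown, and "the series" means these compounds.

compound 1 `COc1cc(/C=C/C(=O)OCCCCOc2no[n+]([O-])c2S(=O)(=O)c2ccccc2)ccc1O` gives 400 nM
compound 2 `COc1cc(/C=C/C(=O)OCCCCCCO[N+](=O)[O-])ccc1O` gives 37400 nM

In a functional assay on A549 cells (Homo sapiens) for cytotoxicity, read by resazurin assay, with a stated time of 72 h (a higher number here means a weaker inhibitor, a lower number a stronger inhibitor), compound 2 stands highest of the two at 37400 nM and lies beyond the scatter from its nearest neighbour, compound 1. Compound 3 `COc1cc(/C=C/C(=O)OCCCCCO[N+](=O)[O-])ccc1O` is still unmeasured. It differs from compound 2 as follows: nitrooxy in place of (nitrooxy)methyl on a saturated chain carbon, five bonds along the chain from an oxygen next to a carbonyl group with nitrooxy in place of (nitrooxy)methyl on a saturated chain carbon. For the measured compounds named here, no measured pair shows what such a change does, so no firm direction can be given. The expected 1.1-fold higher number from compound 2 to compound 3 (0.03 log units; within the scatter) is none beyond the scatter in this assay for now. Compound 3 is estimated at 40000 nM (expected range 15000 nM to 90000 nM).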

Compound 3, half-maximal inhibitory concentration: 6390 nM
The estimate for compound 3 lay 6.3-fold (0.80 log units) above the measured number; the whole stated range lies above it.
By their numbers in this assay, from the lowest: compound 1; then compound 3; then compound 2.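

For the compounds shown here, replacing (nitrooxy)methyl with nitrooxy on a saturated chain carbon, five bonds along the chain from an oxygen next to a carbonyl group, gives the first one-place comparison in this assay, with a 5.9-fold lower number from compound 2 to compound 3 (0.77 log units; beyond the scatter). The length of this nitrooxy chain therefore matters at this position, and the shorter chain gives the lower number. No available evidence bears on this step.

Going by these compounds, whether a still shorter chain, a longer chain, or an amine or carboxylic acid in place of nitrooxy would lower the number further remains open. Compound 1 differs from compound 3 in more than one place, so it cannot show how the two chain ends compare.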